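A few compounds are considered here, and "the series" means these few. Any claim that something is new, unique, unknown or untested is made for them only; others in the source may bear on it.

Working notes on the series around compound 1 `NNC(=O)c1c(N)sc2c1CCCCCC2` in a functional assay on CHO cells for agonist activity at adenosine receptor A1 (Homo sapiens), read by ERK phosphorylation, tested at 3 uM; on this read-out lower numbers stand for a weaker effect and higher numbers for a stronger effect at the one concentration tested. Compound 1 gives 48%, the second highest of the three numbers in hand. Compound 2 `Nc1sc2c(c1C(=O)NNc1ccccc1)CCCCCC2` gives 47%, and the step of a number 1 percentage points lower from compound 1 to compound 2 (within the scatter) shows that phenyl in place of hydrogen on an amine nitrogen leaves the read-out unchanged. Going by the values given here, compound 3 `Cc1ccc(C(=O)c2c(N)sc3c2CCCC3)cc1` gives 70%; it carries an aryl ketone rather than a hydrazide and a smaller saturated ring, so its two values with compound 1 are noted but no single-point step connects them.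

Compound 4 `Nc1sc2c(c1C(=O)c1ccccc1)CCCCCC2` is not yet measured. The change from compound 1 is phenyl in place of aminoamino on a carbonyl carbon. Among the compounds with values here, the only measured step, the one from compound 1 to compound 2, touches the amine nitrogen rather than the carbonyl carbon and lies within the scatter, so it bears only loosely on this change. Compound 3 shows that an aryl ketone on this kind of core can give a higher number than compound 1. The expectation for compound 4 is therefore a moderate rise, a number 14 percentage points higher from compound 1 to compound 4 (beyond the scatter), with wide uncertainty. Compound 4 is estimated at 62%, between 45% and 78%.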

Compound 4, a percentage reported as activity, at one concentration (the size of the read-out at that concentration, not a potency): 49%
Estimate against measurement, compound 4: 13 percentage points above, within the range that was stated.
By their numbers in this assay, from the lowest: compounds 2, 1 and 4 (each within the scatter of the next); then compound 3.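

In this assay, phenyl in place of aminoamino on a carbonyl carbon, a number 1 percentage points higher from compound 1 to compound 4 (within the scatter), leaves the read-out unchanged, so at this place the number does not depend on keeping the aminoamino group with its hydrogen-bond donors. A six-membered aromatic ring of carbon only, with no hydrogen-bond donors or acceptors, serves here as well as the two nitrogens, and the aryl ketone alone does not bring compound 4 up to the number of compound 3. No measurement at hand accounts for this flat result.

Compound 3 differs from compound 4 in both the saturated ring and the methyl on its phenyl, so neither change can be credited on its own with its higher number. Also open, on these data alone, is whether a smaller group on the carbonyl carbon, such as a hydroxyl or an ethyl chain, would keep the read-out at this level.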